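A Further Methyl Group on Compound 2

A few compounds are considered here, and "the series" means these few. Any claim that something is new, unique, unknown or untested is made for them only; others in the source may bear on it.

In a functional assay on the whole organism with Canis familiaris (Canis lupus familiaris) as the target (a lower number here means that less compound is needed, a higher number that more compound is needed for the effect), compound 1 `c1ccc(-c2nc3cc[nH]cc-3n2)cc1` gives 2.5 mg/kg, and compound 2 `Cc1ccccc1-c1nc2cc[nH]cc-2n1`, which carries one methyl group more, gives 2.2 mg/kg. With only these two numbers available, compound 2 stands level with compound 1, since the values lie within the scatter of each other.

Compound 3 `Cc1ccc(-c2nc3cc[nH]cc-3n2)c(C)c1` extends compound 2 by one further change, a methyl in place of hydrogen on an aromatic carbon. Within the data shown here, the only measured step that bears on this is the same kind of replacement, made at another carbon of that ring. That step, a 1.1-fold lower number from compound 1 to compound 2 (0.06 log units; within the scatter), gives no sign of a shift in this assay. It is a single pair, however, and the data do not show how a methyl at the new place behaves, so the expectation remains loose. No step beyond the scatter is expected, and the estimated change is a 1.0-fold lower number from compound 2 to compound 3 (0.02 log units; within the scatter). For compound 3, the expected value is 2.1 mg/kg, with an estimated range from 1 mg/kg to 4.5 mg/kg.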

Compound 3, dose for half-maximal effect: 1.4 mg/kg
The estimate for compound 3 lay 1.5-fold (0.18 log units) above the measured number; the measured number falls inside the stated range.
By their numbers in this assay, from the lowest: compounds 3, 2 and 1 (each within the scatter of the next).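

In this assay the new methyl gives a 1.6-fold lower number from compound 2 to compound 3 (0.20 log units; within the scatter) and so leaves compound 3 level with compound 2, which shows that a methyl on this aromatic carbon, meta to a methyl group and para to a group of 9 heavy atoms, is accepted with no shift beyond the scatter. Read with a 1.1-fold lower number from compound 1 to compound 2 (0.06 log units; within the scatter) as the earlier step, this makes two replacements of hydrogen by methyl at two different places on the six-membered aromatic ring, and both stay within the scatter, so the second methyl adds no measurable change to what the first one showed. No measurement shown here offers an explanation for the size of either step.

The compounds shown leave open whether this place accepts only methyl, since a chlorine, a methoxy group, an amine, a carboxylic acid or a longer chain could stay level with compound 2 or move beyond the scatter. They also leave open how a methyl at this place behaves when the other methyl group is absent.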